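This account rests on a few compounds, and the source may have more. Where it says the series, first, only, none or still open, it means among the compounds named here.

Compound 2 `CC#CCn1c(N2CCC[C@@H](N)C2)cc(=O)n(Cc2cc(Br)ccc2C(=O)O)c1=O` is examined in an ADME assay on Sf9 cells for inhibition of Dipeptidyl peptidase 9 (Homo sapiens), read by fluorescence, with stated times of 60 s and 20 min (on this read-out lower numbers stand for stronger inhibition and higher numbers for weaker inhibition), where compound 2 gives only a limit of > 100000 nM. Its close relative, compound 1 `CC#CCn1c(N2CCC[C@@H](N)C2)cc(=O)n(Cc2ccccc2C(=O)O)c1=O`, likewise gives only a limit of > 100000 nM. The step that the two limits leave unreadable from compound 1 to compound 2 therefore cannot be read, since the limit of > 100000 nM in this assay, at which 2 of the 2 values shown sit, holds both values. Compound 3 `CC#CCn1c(N2CCC[C@@H](N)C2)cc(=O)n(Cc2cc(Br)ccc2C(=O)OC)c1=O` differs from compound 2 by methyl in place of hydrogen on an oxygen next to a carbonyl group. Going by the values given here, no measured step bears on this change, and the one comparison available shows two limits and nothing more. Compound 3 is expected to remain at or beyond that limit, with a step that the limit leaves unreadable from compound 2 to compound 3 carrying little weight. The estimate for compound 3 is 150000 nM, ranging from 30000 nM to 800000 nM.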

Compound 3, half-maximal inhibitory concentration: > 100000 nM
Compound 3 was reported as a limit (the forecaster's own chance of this, stated with the estimate: 85%); the middle value is on the limit's open side.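

No step can be read from compound 2 to compound 3, since both stop at the same limit: the limit of > 100000 nM in this assay, at which 3 of the 3 values shown sit.

The compounds shown leave open how strongly compound 1, compound 2 or compound 3 inhibits the enzyme, and whether changing carboxy to methoxycarbonyl makes any difference.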